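Removing a Methoxy Group From an Inactive Scaffold

The compounds below may be only part of what the source reports. "The series", "measured", "known", "first", "only" and "open" are said of these compounds alone.

Measured compounds:
Compound 2: `COc1cccc(-c2nn3cc(-c4cccc(N)c4)nc3s2)c1` — > 250000 nM
Compound 1: `COc1ccc(-c2nn3cc(-c4cccc(N)c4)nc3s2)cc1` — >= 250000 nM

Both compounds were tested in a functional assay on CCRF-CEM cells (Homo sapiens) for inhibition, read by cell counting, with a stated time of 3 days; a lower number here means a stronger inhibitor, a higher number a weaker inhibitor. For compound 2 the value > 250000 nM is a limit of the assay and not a measured number, so compound 2 shows no inhibition that the assay can resolve. For compound 1 the value >= 250000 nM is likewise a limit. Compound 2 therefore stands at the edge of what can be reported, with no numerical potency to build on.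

Compound 3 `Nc1cccc(-c2cn3nc(-c4ccccc4)sc3n2)c1` differs from compound 2 by hydrogen in place of methoxy on an aromatic carbon, in words hydrogen in place of methoxy on an aromatic carbon. Among the compounds with values here, no measured step between two compounds is available to gauge this change. With compound 2 already at a limit, the step of a number no higher from compound 2 to compound 3 (the limit leaves the size open) is expected to be none beyond the scatter, leaving compound 3 unresolved as well. Compound 3 is therefore expected to give about 250000 nM, in a range from 80000 nM to 600000 nM, most likely reported only as a limit.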

Compound 3, half-maximal inhibitory concentration: 33000 nM
Compound 3: middle estimate off by 7.6-fold (0.88 log units), on the high side; measured number below the stated range.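

In this assay, only compound 3 gives a measured number, so the methoxy group does matter: hydrogen in its place gives an at least 7.5-fold lower number from compound 2 to compound 3 (0.87 log units; beyond the scatter), and the same change gives an at least 7.5-fold lower number from compound 1 to compound 3 (0.87 log units; beyond the scatter). The first step is a minimum, not an exact size, because compound 2 stands at a limit of the assay: the limit of > 250000 nM in this assay, at which 1 of the 3 values shown sits. The second step is also a minimum, because compound 1 likewise stands at a limit: the limit of >= 250000 nM in this assay, at which 1 of the 3 values shown sits.

Within the data shown here, the three compounds do not show why removing the methoxy group helps, since they hold only that group and hydrogen at this spot. On these data alone, whether a fluorine atom, a hydroxyl or an ethoxy group on the same ring would behave like hydrogen or like methoxy remains open.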